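From methoxy to phenyl on the terminal ring

The source may hold more compounds than are shown below. What is called first, only, known or untested is meant among the compounds shown, and "the series" means these compounds.

Compound 1 `COc1cccc(NC(=O)Nc2ccc(Nc3ncnc4c3OCCN4)cc2)c1` stands in a functional assay on BaF3 cells (Mus musculus) for inhibition, read by MTT assay, with a stated time of 3 days (a lower number here means a stronger inhibitor of growth, a higher number a weaker inhibitor of growth), at > 10000 nM as a limit of the assay, not as a number. Compound 2 `Cc1cc(C)cc(NC(=O)Nc2ccc(Nc3ncnc4c3OCCN4)cc2)c1` likewise gives > 10000 nM as a limit. For the measured compounds named here, compound 3 `O=C(Nc1ccc(Nc2ncnc3c2OCCN3)cc1)Nc1cc(Cl)cc(Cl)c1` reads 10000 nM as the only true number in the set.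

Compound 4 `O=C(Nc1ccc(Nc2ncnc3c2OCCN3)cc1)Nc1cccc(-c2ccccc2)c1` carries phenyl in place of methoxy on an aromatic carbon, meta to a large group, and phenyl in place of methoxy on an aromatic carbon gives the count of that change.

The three measured steps all concern the aryl group on the amide-type nitrogen, so they bear most directly on this change. Their sizes cannot be read: a step that the two limits leave unreadable from compound 1 to compound 2 is left unreadable by its two limits, while a number no higher from compound 1 to compound 3 (the limit leaves the size open) and also a number no higher from compound 2 to compound 3 (the limit leaves the size open) have only a direction, with the size left open.

Compound 3 stands at 10000 nM. The other two values are limits of the assay, and no step beyond the scatter is expected in this assay for this change. The expected step is a number no higher from compound 1 to compound 4 (the limit leaves the size open) and another limit is the most likely report. Compound 4 is estimated at 10000 nM with an expected range of 4000 nM to 25000 nM for growth inhibition.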

Compound 4, concentration for 50% growth inhibition: > 10000 nM
Compound 4 gave a limit, no number (the forecaster's own chance of this, stated with the estimate: 70%); the middle value sits exactly at the limit.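

No size can be read for the step from methoxy to phenyl, because compound 1 and compound 4 each give only a limit of the assay, not a number: the limit of > 10000 nM in this assay, at which 3 of the 4 values shown sit.

The compounds shown leave open whether phenyl and methoxy on this ring differ at all in this assay.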